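Triazole-linked hydroxamate in the stilbene series

The source may hold more compounds than are shown below. What is called first, only, known or untested is meant among the compounds shown, and "the series" means these compounds.

For the measured compounds named here, compound 3 `COc1cc(/C=C/c2ccc(OCCCCCCC(=O)NO)cc2)cc(OC)c1` gives 1070 nM in a functional assay on HCT-116 cells (Homo sapiens) for cytotoxicity, read by MTT assay, with a stated time of 48 h (on this read-out higher numbers stand for weaker inhibition and lower numbers for stronger inhibition), and shows the lowest number of the three measured members. Compound 1 `COc1cc(/C=C/c2ccc(OCCCC(=O)NO)cc2)cc(OC)c1` gives 5200 nM and compound 2 `COc1cc(/C=C/c2ccc(OCCCCC(=O)NO)cc2)cc(OC)c1` gives 3350 nM. The measured steps are a 1.6-fold lower number from compound 1 to compound 2 (0.19 log units; within the scatter), a 4.9-fold lower number from compound 1 to compound 3 (0.69 log units; beyond the scatter) and a 3.1-fold lower number from compound 2 to compound 3 (0.50 log units; beyond the scatter): lengthening the chain between the oxygen on the aromatic ring and the hydroxycarbamoyl group lowers the number, modestly.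

Compound 4 `COc1cc(/C=C/c2ccc(OCCc3cn(CC(=O)NO)nn3)cc2)cc(OC)c1` differs from compound 3 as follows. 1-((hydroxycarbamoyl)methyl)-1H-1,2,3-triazol-4-yl in place of 4-(hydroxycarbamoyl)butyl on a saturated chain carbon, two bonds along the chain from an oxygen on an aromatic ring The group that enters carries one five-membered aromatic ring with 3 hetero atoms; the group that leaves has no ring. Going by the values given here, no measured step covers a ring inserted into this chain, so the three steps above bear on it only in that the overall chain length is kept comparable. A step within the scatter is expected, perhaps slightly toward higher numbers. For compound 4 the estimate is 1600 nM, between 500 nM and 5000 nM, meaning a step of a 1.5-fold higher number from compound 3 to compound 4 (0.17 log units; within the scatter) expected from compound 3.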

Compound 4, half-maximal inhibitory concentration: 7440 nM
Beside the measured number, compound 4's estimate is 4.7-fold (0.67 log units) below it, outside the stated range (above it).
By their numbers in this assay, from the lowest: compound 3; then compounds 2, 1 and 4 (each within the scatter of the next, the first and the last beyond it).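

The triazole-bearing chain does not read as a saturated chain of comparable reach in this assay: 1-((hydroxycarbamoyl)methyl)-1H-1,2,3-triazol-4-yl in place of 4-(hydroxycarbamoyl)butyl gives (a 7.0-fold higher number from compound 3 to compound 4 (0.84 log units; beyond the scatter)), which gives up the whole gain seen on lengthening the saturated chain. Against the shorter chains, the same ring gives (a 2.2-fold higher number from compound 2 to compound 4 (0.35 log units; beyond the scatter)) and (a 1.4-fold higher number from compound 1 to compound 4 (0.16 log units; within the scatter)), so compound 4 reads with compound 1, the shortest chain, and not with compound 3, the longest. On this position, then, chain length alone does not carry the read-out once the ring enters.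

Nothing at hand gives a reason for this step. Still open, on these data alone, is how a triazole carrying 3-(hydroxycarbamoyl)propyl in place of its (hydroxycarbamoyl)methyl would read, which would separate the ring itself from the short chain that ends in the hydroxycarbamoyl group.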